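This account rests on a few compounds, and the source may have more. Where it says the series, first, only, none or still open, it means among the compounds named here.

Series notes. Within the data shown here, compound 3 `O=C(Nc1ccc(NCc2ccc(O)cc2)cc1Cl)c1cc(Cl)ccc1O` in an ADME assay on A549 cells (Homo sapiens) for cytotoxicity, read by resazurin assay, with a stated time of 48 h (on this read-out lower numbers stand for higher toxicity in this test and higher numbers for lower toxicity in this test), gives 116000 nM, the second highest of the three numbers so far. Compound 1 `CC1(Nc2ccc(NC(=O)c3cc(Cl)ccc3O)c(Cl)c2)CCCC1` gives 157000 nM, and a 1.4-fold lower number from compound 1 to compound 3 (0.13 log units; within the scatter), so these two cannot be ordered against each other. Compound 2 `CCCN(CCC)c1ccc(NC(=O)c2cc(Cl)ccc2O)c(Cl)c1` gives 10700 nM, and an 11-fold higher number from compound 2 to compound 3 (1.04 log units; beyond the scatter). The next step leads to compound 4 `O=C(Nc1ccc(N(CCCO)CCCO)cc1Cl)c1cc(Cl)ccc1O`: bis(3-hydroxypropyl)amino in place of (4-hydroxybenzyl)amino on an aromatic carbon. Among the measured compounds shown here, the steps that bear on it alter the same position on the shared core: an 11-fold higher number from compound 2 to compound 3 (1.04 log units; beyond the scatter) and a 15-fold lower number from compound 1 to compound 2 (1.17 log units; beyond the scatter), both large, whereas a 1.4-fold lower number from compound 1 to compound 3 (0.13 log units; within the scatter) stays small. Compound 4 carries a nitrogen bearing two chains, as compound 2 does, yet each chain ends in a hydroxyl, as the group of compound 3 does. For the measured compounds named here, no measured pair tests this combination, so a lower number is expected, but not as far down as compound 2, because compound 2 gives 10700 nM with dipropylamino rather than bis(3-hydroxypropyl)amino. Compound 4 is expected to give 45000 nM, within 15000 nM to 140000 nM. The expected step is a 2.6-fold lower number from compound 3 to compound 4 (0.41 log units; beyond the scatter).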

Compound 4, half-maximal cytotoxic concentration: 114000 nM
For compound 4 the middle estimate is 2.5-fold (0.40 log units) below the measured one; the measured number falls inside the stated range.
By their numbers in this assay, from the lowest: compound 2; then compounds 4, 3 and 1 (each within the scatter of the next).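

In this assay, bis(3-hydroxypropyl)amino cannot be told apart from (4-hydroxybenzyl)amino on this aromatic carbon (a 1.0-fold lower number from compound 3 to compound 4 (0.01 log units; within the scatter)), nor from (1-methylcyclopentyl)amino (a 1.4-fold lower number from compound 1 to compound 4 (0.14 log units; within the scatter)). A nitrogen bearing two chains therefore does not by itself go with the low number: only the terminal hydroxyls separate compound 4 from compound 2, and that change is a large step (an 11-fold higher number from compound 2 to compound 4 (1.03 log units; beyond the scatter)). The data given here offer no explanation for this difference.

Still open, from the compounds shown here alone, is whether one 3-hydroxypropyl chain paired with one propyl chain gives the number of compound 2 or that of compound 4. Also open, going by these compounds, is whether a terminal amine, a terminal carboxylic acid or a longer chain ending in hydroxyl behaves as bis(3-hydroxypropyl)amino does at this position.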